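The compounds below may be only part of what the source reports. "The series", "measured", "known", "first", "only" and "open" are said of these compounds alone.

Of the compounds shown here, three sharing one core have been measured in a functional assay on A549 cells (Homo sapiens) for inhibition, read by MTT assay, with a stated time of 72 h; a higher number here means a weaker inhibitor, a lower number a stronger inhibitor. Compound 1 (`COc1ccc(-c2nnc(SCCCN3CCN(c4nc5ccccc5o4)CC3)o2)cc1`) gives 93500 nM. Compound 2 (`c1ccc(-c2nnc(SCCCN3CCN(c4nc5ccccc5o4)CC3)o2)cc1`) gives 108000 nM, and compound 3 (`COc1ccc(-c2nnc(SCCCN3CCN(c4nc5ccccc5s4)CC3)o2)cc1`) gives 90300 nM. Compound 3 thus stands level with the other two, its gaps to both lying within the scatter.

Compound 4 (`CC(C)(C)Oc1ccc(-c2nnc(SCCCN3CCN(c4nc5ccccc5s4)CC3)o2)cc1`) departs from compound 3 in one place: tert-butyl in place of methyl on an oxygen on an aromatic ring. In words, tert-butyl stands in place of methyl on an oxygen on an aromatic ring, so that methoxy becomes tert-butoxy.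

Among the measured compounds shown here, two measured steps bear on this. The closer one touches the same methoxy: a 1.2-fold higher number from compound 1 to compound 2 (0.06 log units; within the scatter), with hydrogen in place of methoxy. The other, a 1.0-fold lower number from compound 1 to compound 3 (0.02 log units; within the scatter), has 1,3-benzothiazol-2-yl in place of 1,3-benzoxazol-2-yl on an amine nitrogen in a ring. Both stay within the scatter, though neither puts tert-butyl at this place, so the data do not test that group directly. No step beyond the scatter is therefore expected in this assay, in either direction. The estimated step is a 1.1-fold lower number from compound 3 to compound 4 (0.03 log units; within the scatter). The expected value for compound 4 is 85000 nM, within an estimated range from 45000 nM to 150000 nM.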

Compound 4, half-maximal inhibitory concentration: 71600 nM
The estimate for compound 4 lay 1.2-fold (0.07 log units) above the measured number; measured number inside the range.
By their numbers in this assay, from the lowest: compounds 4, 3, 1 and 2 (each within the scatter of the next).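

In this assay, among the compounds shown here, the step of a 1.3-fold lower number from compound 3 to compound 4 (0.10 log units; within the scatter) gives the first direct reading of tert-butyl on this oxygen on an aromatic ring, and it shows that methoxy can become tert-butoxy with no step beyond the scatter. The earlier compounds shown here had tested this place only by removing the methoxy, in a 1.2-fold higher number from compound 1 to compound 2 (0.06 log units; within the scatter), and that step was read with 1,3-benzoxazol-2-yl on the amine nitrogen, whereas the new one is read with 1,3-benzothiazol-2-yl there; on each of these two backgrounds, the change at this place stays within the scatter. No measurement bears on why the number in this assay responds so little to the change at this position.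

The compounds shown leave open whether an amine, a hydroxyl or a carboxylic acid in place of the tert-butoxy would move the number in this assay beyond the scatter. They also leave open whether tert-butyl would behave the same way with 1,3-benzoxazol-2-yl on the amine nitrogen, and whether any change elsewhere on the shared core, such as a longer chain, would produce a step beyond the scatter.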